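A few compounds are considered here, and "the series" means these few. Any claim that something is new, unique, unknown or untested is made for them only; others in the source may bear on it.

In a functional assay on MCF7 cells (Homo sapiens) for cytotoxicity, read by MTT assay, with a stated time of 72 h (on this read-out lower numbers stand for stronger inhibition and higher numbers for weaker inhibition), compound 1 `COc1cccc(/C=C2\CCC/C(=C\c3cccc(Cl)c3)C2=O)c1OC` gives 12000 nM. Compound 2 `COc1cccc(/C=C2\CCC/C(=C\c3cccc(Cl)c3Cl)C2=O)c1OC` stands at > 20000 nM, which is a limit of the assay and not a number. The next compound, compound 3 `COc1cccc(/C=C2\CCC/C(=C\c3ccc(Cl)cc3Cl)C2=O)c1OC`, has the same atoms joined differently: 2,4-dichlorophenyl in place of 2,3-dichlorophenyl on a double-bonded chain carbon bound to a double-bonded ring carbon. The change is 2,4-dichlorophenyl in place of 2,3-dichlorophenyl, on a double-bonded chain carbon bound to a double-bonded ring carbon. Going by the values given here, only one measured step bears on it, an at least 1.6-fold higher number from compound 1 to compound 2 (0.22 log units; that floor lies within the scatter). That step added a chloro, whereas this change adds none, and its floor stays within the scatter. No step beyond the scatter is therefore expected in this assay, in either direction, and a further limit would be no surprise. The expected change is a number no higher from compound 2 to compound 3 (the limit leaves the size open). The estimate for compound 3 is 20000 nM, with an expected range of 9000 nM to 40000 nM.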

Compound 3, half-maximal inhibitory concentration: > 20000 nM
Compound 3: only a limit was reported; the forecaster's own chance of this, stated with the estimate: 50%; the middle value sits exactly at the limit.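

In this assay, the shift from 2,3-dichlorophenyl to 2,4-dichlorophenyl on a double-bonded chain carbon bound to a double-bonded ring carbon yields a second result without a number, so the step between these two dichlorophenyl compounds cannot be read. Set against the 3-chlorophenyl group, the new group gives an at least 1.6-fold higher number from compound 1 to compound 3 (0.22 log units; that floor lies within the scatter). The two dichlorophenyl arrangements therefore add a second limit at this place, and neither yields a measurable value: the limit of > 20000 nM in this assay, at which 2 of the 3 values shown sit.

The compounds shown leave open whether either dichlorophenyl group truly differs from 3-chlorophenyl or from the other by more than the scatter. They also leave open how this assay would read with an amine or a carboxylic acid in place of a chloro on this aromatic ring.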